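The source may report more compounds than this note shows. Statements on the series, on what has been measured and on what is new or still open speak of the compounds shown alone.

Measured compounds:

Compound 1 `Cn1c(=O)c2[nH]c(SCC(=O)c3ccccc3)nc2n(C)c1=O`, which in a functional assay on A549 cells (Homo sapiens) for inhibition, read by MTT assay, with a stated time of 48 h (a higher number here means a weaker inhibitor, a lower number a stronger inhibitor), gives 6700 nM.
Compound 2 `COc1ccc(C(=O)CSc2nc3c([nH]2)c(=O)n(C)c(=O)n3C)cc1`, which in this assay gives 7900 nM.
Compound 3 `Cn1c(=O)c2[nH]c(SC/C(=N/O)c3ccccc3)nc2n(C)c1=O`, which in this assay gives 6100 nM.

Compound 1 and compound 2 differ in one place only: methoxy in place of hydrogen on an aromatic carbon. The step of a 1.2-fold higher number from compound 1 to compound 2 (0.07 log units; within the scatter), so the two numbers are not distinguishable in this test. Compound 3 carries the same core as compound 1 and compound 2 but with a different side group; the difference between compound 1 and compound 3 is not broken down here. Its number sits close to those of compound 1 and compound 2, all three within the usual scatter of one another.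

Compound 4 `COc1ccc(/C(CSc2nc3c([nH]2)c(=O)n(C)c(=O)n3C)=N\O)cc1` has not yet been tested. It relates to compound 3 exactly as compound 2 relates to compound 1: methoxy in place of hydrogen on an aromatic carbon. The two place descriptions agree word for word, so this is the same change made on a second pair.

Because the earlier occurrence of this change gave a 1.2-fold higher number from compound 1 to compound 2 (0.07 log units; within the scatter), the expectation is that the step from compound 3 to compound 4 is likewise small, a 1.1-fold higher number from compound 3 to compound 4 (0.06 log units; within the scatter), which rests only on that single earlier pair. On that basis compound 4 is estimated to give about 7000 nM in this assay, with a plausible range from 4000 nM to 12000 nM.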

Compound 4, half-maximal inhibitory concentration: 1500 nM
Compound 4: middle estimate off by 4.7-fold (0.67 log units), on the high side; measured number below the stated range.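

In this assay, methoxy in place of hydrogen on an aromatic carbon gives a 4.1-fold lower number from compound 3 to compound 4 (0.61 log units; beyond the scatter), so on the core of compound 3 this change goes with a stronger inhibitor, a modest but real shift. The same change on the core of compound 1 gave no shift that could be told apart from scatter, which means that its effect did not carry over unchanged from one core to the other: the same change on two cores in this assay, a 1.2-fold higher number (0.07 log units; within the scatter) from compound 1 to compound 2 and a 4.1-fold lower number (0.61 log units; beyond the scatter) from compound 3 to compound 4, 4.8-fold (0.68 log units) apart, beyond the scatter of two such steps. This shows that, in this series, the result of the change on one core is a poor guide to its result on the other, but it does not show why the two differ, and two pairs cannot establish a rule for other cores or other changes.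

The compounds shown carry only hydrogen or methoxy at this place on the ring, so it remains open whether a chlorine, a hydroxyl or an ethoxy group there would also behave differently on the two cores. Going by these compounds, it also remains open whether the lower number of compound 4 would hold up in repeat measurements or in cells other than those of this test.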